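A few compounds are considered here, and "the series" means these few. Any claim that something is new, unique, unknown or untested is made for them only; others in the source may bear on it.

In a functional assay on OPM-2 cells (Homo sapiens) for inhibition, with a stated time of 24 h, in the presence of a further agent that is not named here (a higher number here means a weaker inhibitor, a lower number a stronger inhibitor), compound 1 (`C[C@@H]1[C@@H](C)CCC[C@H](C2OCC(N(C)C)CO2)[C@@H]2CC[C@H]2CN2C[C@@]3(CCCc4cc(Cl)ccc43)COc3ccc(cc32)C(=O)NS1(=O)=O`) gives 19 nM and compound 2 (`C[C@@H]1[C@@H](C)C/C=C/[C@H](O)[C@@H]2CC[C@H]2CN2C[C@@]3(CCCc4cc(Cl)ccc43)COc3ccc(cc32)C(=O)NS1(=O)=O`) gives 140 nM. Compound 3 (`C[C@@H]1CC/C=C/[C@H](O)[C@@H]2CC[C@H]2CN2C[C@@]3(CCCc4cc(Cl)ccc43)COc3ccc(cc32)C(=O)NS1(=O)=O`) gives 300 nM, the highest of the three numbers. Compound 4 (`CC[C@@H]1CC/C=C/[C@H](O)[C@@H]2CC[C@H]2CN2C[C@@]3(CCCc4cc(Cl)ccc43)COc3ccc(cc32)C(=O)NS1(=O)=O`) is the next to be tested, and it differs from compound 3 by a single change: methyl in place of hydrogen on a saturated chain carbon bound to a saturated ring carbon. This is methyl in place of hydrogen on a saturated chain carbon bound to a saturated ring carbon, so that methyl becomes ethyl.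

Among the compounds with values here, only one measured step bears on this change, and it lies elsewhere in the structure: a 2.1-fold higher number from compound 2 to compound 3 (0.33 log units; beyond the scatter). There, hydrogen took the place of methyl on a saturated ring carbon, a modest step. Read in reverse, an added methyl went with a lower number, but the data do not show whether this holds at the new place. A modest step towards a lower number is therefore expected, and it may not clear the scatter. The expected step is a 1.4-fold lower number from compound 3 to compound 4 (0.15 log units; within the scatter). For compound 4 the estimate is 210 nM, with an expected range of 90 nM to 480 nM.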

Compound 4, half-maximal inhibitory concentration: 420 nM
For compound 4 the middle estimate is 2.0-fold (0.30 log units) below the measured one; the measured number falls inside the stated range.
By their numbers in this assay, from the lowest: compound 1; then compound 2; then compounds 3 and 4 (each within the scatter of the next).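

In this assay, the step from methyl to ethyl on a saturated chain carbon bound to a saturated ring carbon comes to a 1.4-fold higher number from compound 3 to compound 4 (0.15 log units; within the scatter), so this position takes the added methyl with no change that can be read. The earlier step, a 2.1-fold higher number from compound 2 to compound 3 (0.33 log units; beyond the scatter), concerned a saturated ring carbon and lay beyond the scatter, and the link it suggested between an added methyl and a lower number does not carry over to this place. Nothing measured here accounts for this result.

From the compounds shown here alone, whether a longer chain such as propyl, an amine or a carboxylic acid at this carbon would also leave the number in this range remains open. Going by these compounds, it is equally open whether ethyl would read the same way in a compound that also carries the ring methyl of compound 2.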